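Methylated imidazole in place of the free imidazole

A few compounds are considered here, and "the series" means these few. Any claim that something is new, unique, unknown or untested is made for them only; others in the source may bear on it.

The two measured compounds share a common core and differ in the five-membered ring and in the methyl pattern on the central ring. Compound 1 `Cc1ccc(-c2cnc(C)n2C)cc1NC(=O)c1ccc(OCc2ccccn2)cc1` gives 12% in a functional assay on the whole organism (COLO 205 cells) for inhibition, with Mus musculus as the target, read by polymerase chain reaction, in a xenograft, with a stated time of 8 h, at a dose of 40 mg/kg by the oral route; a higher number here means more inhibition at the dose given (going by the name of the read-out), a lower number less inhibition. Compound 2 `Cc1cc(C)c(-c2ncc[nH]2)cc1NC(=O)c1ccc(OCc2ccccn2)cc1` gives 88% in this assay, which is the higher of the two numbers; the gap to compound 1 lies beyond the usual scatter. Because the two compounds differ in more than one place, the numbers alone do not tell which change carries the gap.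

Compound 3 `Cc1cc(C)c(-c2cn(C)cn2)cc1NC(=O)c1ccc(OCc2ccccn2)cc1` is not yet measured. It differs from compound 2 by 1-methyl-1H-imidazol-4-yl in place of 1H-imidazol-2-yl on an aromatic carbon. The change removes the only hydrogen-bond donor of the five-membered ring and the ring is attached through a different carbon; compound 1, the only other methylated imidazole here, gives 12%, though it also carries a different methyl pattern.

A downward step of moderate size is expected from compound 2 to compound 3 in this assay, namely a number 38 percentage points lower from compound 2 to compound 3 (beyond the scatter). Compound 3 is estimated at 50%, within 15% to 85%.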

Compound 3, a percentage reported as inhibition, in the whole organism at one dose (the size of the read-out at that dose, not a potency): 87%
For compound 3 the middle estimate is 37 percentage points below the measured one, outside the stated range (above it).
By their numbers in this assay, from the lowest: compound 1; then compounds 3 and 2 (each within the scatter of the next).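

Among the compounds shown here, the swap of 1H-imidazol-2-yl for 1-methyl-1H-imidazol-4-yl on this aromatic carbon, ortho to one methyl group and para to another, gives in this assay a number 1 percentage points lower from compound 2 to compound 3 (within the scatter), and this is the first reading at this position in which only one place differs. The entering group has 0 hydrogen-bond donors where the leaving group has 1, and it is attached through a different ring carbon, yet neither difference moves the number beyond the usual scatter at this single oral dose, so at this position the free ring hydrogen is not required for the read-out. Nothing at hand explains why the two groups read alike.

The compounds shown leave open how much of the gap separating compound 1 from compound 2 belongs to the five-membered ring and how much to the methyl pattern on the central ring, as no pair isolates either change. They also leave open how this aromatic carbon would respond to a group other than an imidazole, such as a primary amine, a carboxylic acid or a longer alkyl chain.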